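The compounds below may be only part of what the source reports. "The series", "measured", "known", "first", "only" and "open" are said of these compounds alone.

Within the data shown here, in a functional assay on HCT-116 cells (Homo sapiens), read by MTT assay, with a stated time of 72 h (on this read-out lower numbers stand for stronger inhibition and higher numbers for weaker inhibition), compound 3 `Nc1nc(N)c2c(-c3cc4ccccc4o3)cn([C@@H]3O[C@H](CO)[C@@H](O)[C@H]3O)c2n1` gives 14000 nM, the only number so far. Compound 1 `Nc1nc(N)c2c(-c3ccsc3)cn([C@@H]3O[C@H](CO)[C@@H](O)[C@H]3O)c2n1` returns only a limit, > 20000 nM. Compound 2 `Nc1nc(N)c2c(-c3ccoc3)cn([C@@H]3O[C@H](CO)[C@@H](O)[C@H]3O)c2n1` likewise returns only a limit, > 20000 nM. Both rest at the limit of > 20000 nM in this assay, at which 2 of the 3 values shown sit. The readable steps are an at least 1.4-fold lower number from compound 1 to compound 3 (0.15 log units; that floor lies within the scatter) and an at least 1.4-fold lower number from compound 2 to compound 3 (0.15 log units; that floor lies within the scatter), while a step that the two limits leave unreadable from compound 1 to compound 2. Compound 4 `Nc1nc(N)c2c(-c3ccco3)cn([C@@H]3O[C@H](CO)[C@@H](O)[C@H]3O)c2n1` is not yet measured; it differs from compound 3 by furan-2-yl in place of 1-benzofuran-2-yl on an aromatic carbon. The six-membered aromatic ring of carbon only that leaves with 1-benzofuran-2-yl is what separated compound 3 from compound 2, so with an at least 1.4-fold lower number from compound 2 to compound 3 (0.15 log units; that floor lies within the scatter) in mind the step of a 1.8-fold higher number from compound 3 to compound 4 (0.25 log units; within the scatter) is expected to run toward weaker inhibition. Compound 4 is therefore estimated at 25000 nM, within 10000 nM to 60000 nM, and a limit rather than a number is quite possible.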

Compound 4, half-maximal inhibitory concentration: > 20000 nM
Compound 4 ended at the assay's limit (the forecaster's own chance of this, stated with the estimate: 60%); the middle value does not contradict the limit.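

In this assay, compound 4 returns only a limit, so furan-2-yl gives no readable number at this aromatic carbon. This pair isolates the six-membered aromatic ring of carbon only: its loss gives an at least 1.4-fold higher number from compound 3 to compound 4 (0.15 log units; that floor lies within the scatter), so no difference beyond the scatter is established. The steps among compound 1, compound 2 and compound 4 cannot be read, and most of the series rests at one limit: the limit of > 20000 nM in this assay, at which 3 of the 4 values shown sit.

From the compounds shown here alone, whether 1-benzofuran-2-yl truly differs from the single-ring groups remains open. Also open, going by these compounds, is whether an amine or carboxylic acid on the furan-2-yl ring would give a readable number.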